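Halogen exchange on the benzyl group across two cores

The source may report more compounds than this note shows. Statements on the series, on what has been measured and on what is new or still open speak of the compounds shown alone.

Compound 1 `O=C(CCCCCCn1cc(Nc2ncc3ccn(Cc4ccccc4F)c3n2)cn1)NO` is the reference of the set; in an assay on isolated protein for inhibition of protein deacetylase HDAC6 (Homo sapiens), with a stated time of 60 min (a lower number here means a stronger inhibitor, a higher number a weaker inhibitor), compound 1 gives 8.4 nM. Compound 2 `O=C(CCCCCCn1cc(Nc2ncc3ccn(Cc4ccccc4Cl)c3n2)cn1)NO` differs from compound 1 by chloro in place of fluoro on an aromatic carbon, and in this assay compound 2 gives 41.5 nM, so that the step reads a 4.9-fold higher number from compound 1 to compound 2 (0.69 log units; beyond the scatter). Compound 3 `O=C(CCCCCn1cc(Nc2ncc3ccn(Cc4cccc(F)c4)c3n2)cn1)NO` has another core than compound 1; the difference between the two cores is not broken down here. In this assay compound 3 gives 13.7 nM, which lies close to compound 1 and beyond the scatter against compound 2.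

Compound 4 `O=C(CCCCCn1cc(Nc2ncc3ccn(Cc4cccc(Cl)c4)c3n2)cn1)NO` has not yet been measured. It differs from compound 3 by chloro in place of fluoro on an aromatic carbon. This is the same kind of change as from compound 1 to compound 2, not the same one: there the place is ortho to a large group, here it is meta to a large group. For the measured compounds named here, the step from compound 3 to compound 4 is expected as a 2.9-fold higher number from compound 3 to compound 4 (0.47 log units; beyond the scatter), resting on the single earlier exchange seen in a 4.9-fold higher number from compound 1 to compound 2 (0.69 log units; beyond the scatter), with the different place leaving the size uncertain. Compound 4 is therefore estimated at 40 nM in this assay, with a likely range from 15 nM to 110 nM.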

Compound 4, half-maximal inhibitory concentration: 34.4 nM
Compound 4: the middle estimate sits 1.2-fold (0.07 log units) above what was measured; low and high end bracket the measured number.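

In this assay, chloro in place of fluoro again gives a weaker inhibitor, a 2.5-fold higher number from compound 3 to compound 4 (0.40 log units; beyond the scatter), so the direction of the change carries from the core of compound 1 to the core of compound 3, and the two steps cannot be told apart in size: the same change on two cores in this assay, a 4.9-fold higher number (0.69 log units; beyond the scatter) from compound 1 to compound 2 and a 2.5-fold higher number (0.40 log units; beyond the scatter) from compound 3 to compound 4, 2.0-fold (0.29 log units) apart, within the scatter of two such steps

This rests on two pairs only, and the halogen does not occupy the same place in both: in the pair of compound 3 and compound 4 it is meta to a large group, so core and place vary together and neither can be given a share of the gap between the steps. Nor does agreement within the scatter show that the steps are equal in size, or that the change would behave alike on any further core.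

The compounds shown leave open whether a bromo or a trifluoromethyl group at the same place would extend the trend from fluoro to chloro. On these data alone, how an unsubstituted benzyl group reads on either core also remains open, and with it whether either halogen improves on or weakens the parent.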